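This account rests on a few compounds, and the source may have more. Where it says the series, first, only, none or still open, it means among the compounds named here.

Measured so far:
compound 1, `COc1ccc(-c2nc3c(c(C)nn3-c3ccccc3)c(-c3ccccc3O)c2C#N)cc1`: > 23000 nM
compound 2, `CCc1ccc(-c2nc3c(c(C)nn3-c3ccccc3)c(-c3ccccc3S(C)(=O)=O)c2C#N)cc1`: > 20000 nM
compound 3, `CCc1ccc(-c2nc3c(c(C)nn3-c3ccccc3)c(-c3ccccc3C(=O)OC)c2C#N)cc1`: > 20000 nM

In an ADME assay on BJ cells (Homo sapiens) for cytotoxicity, with a stated time of 72 h (on this read-out lower numbers stand for an effect already at smaller amounts and higher numbers for an effect only at larger amounts of compound), compound 1 gives > 23000 nM, which is a limit of the assay. Compound 2 likewise gives only a limit in this assay, > 20000 nM. Compound 3 also gives only a limit, > 20000 nM. All three results therefore sit at limits: the limit of > 20000 nM in this assay, at which 2 of the 3 values shown sit, and (the limit of > 23000 nM in this assay, at which 1 of the 3 values shown sits). Among the measured compounds shown here, the one step between measured compounds that differ in a single place, a step that the two limits leave unreadable from compound 2 to compound 3, cannot be read as a size, since both of its ends are limits.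

Compound 4, `Cc1nn(-c2ccccc2)c2nc(-c3ccc4c(c3)OCCO4)c(C#N)c(-c3ccccc3O)c12`, differs from compound 1 by 2,3-dihydro-1,4-benzodioxin-6-yl in place of 4-methoxyphenyl on an aromatic carbon. For the measured compounds named here, no measured step covers this change, and the one measured step in this assay is itself unreadable. Every result so far is a limit, so there is no sign of an effect at smaller amounts in any of the three compounds, and compound 4 is expected to behave the same way. The expected step from compound 1, a step that the limit leaves unreadable from compound 1 to compound 4, is therefore none beyond the scatter. The estimate for compound 4 is 30000 nM, between 15000 nM and 80000 nM, and it is most likely to be reported again only as a limit.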

Compound 4, half-maximal effective concentration: > 20000 nM
Compound 4: only a limit was reported; the forecaster's own chance of this, stated with the estimate: 85%; the middle value is on the limit's open side.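

Compound 4 gives only a limit, > 20000 nM. Compound 1 also gives only a limit, > 23000 nM, so no step can be read between these two compounds. The compounds shown leave open at what concentration any of them would harm these cells, and whether this replacement changes that concentration.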